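Group swap from compound 1 to compound 3

The compounds below may be only part of what the source reports. "The series", "measured", "known", "first", "only" and "open" are said of these compounds alone.

- Compound 1 `O=C(N[C@H]1CN(S(=O)(=O)c2ccccc2)C[C@@H]1C(=O)N[C@H]1CCCNC1)c1cn(C2CC2)cn1` gives < 3 mL.min-1.g-1 (a limit)
- Compound 2 `Cc1oc(-c2ccc(C(F)(F)F)cc2)nc1C(=O)N[C@H]1CN(S(=O)(=O)c2ccccc2)C[C@@H]1C(=O)N[C@H]1CCCNC1` gives < 3 mL.min-1.g-1 (a limit)

In an ADME assay on microsomes from liver (Homo sapiens) for metabolic stability (a lower number here means slower removal, a higher number faster removal of the compound), compound 1 gives < 3 mL.min-1.g-1 as its reading, which is a limit of the assay and not a number. Its exact position is therefore unknown. Among the measured compounds shown here, the only other reading is also a limit, so the series so far offers the limit of < 3 mL.min-1.g-1 in this assay, at which 2 of the 2 values shown sit, and no measured step.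

Compound 3 `O=C(N[C@H]1CN(S(=O)(=O)c2ccccc2)C[C@@H]1C(=O)N[C@H]1CCCNC1)c1cc(-c2ccccc2Cl)on1` is still to be measured. On the carbonyl carbon, it carries a new group in place of the 1-cyclopropyl-1H-imidazol-4-yl group of compound 1, as follows: a group of 12 heavy atoms (9 carbon, 1 nitrogen, 1 oxygen, 1 chlorine; one five-membered aromatic ring with 2 hetero atoms, one six-membered aromatic ring of carbon only) in place of a group of 8 heavy atoms (6 carbon, 2 nitrogen; one three-membered non-aromatic ring of carbon only, one five-membered aromatic ring with 2 hetero atoms), on a carbonyl carbon and the rest of the structure stays the same.

The expectation rests on compound 2, whose reading of < 3 mL.min-1.g-1 is a limit too. An expected step of a number no lower from compound 1 to compound 3 (the limit leaves the size open) would stay within the usual scatter, and any movement is expected towards faster removal. Another result reported only as a limit is quite possible. For compound 3 the estimate in this assay is 3 mL.min-1.g-1 with an expected range of 1.5 mL.min-1.g-1 to 8 mL.min-1.g-1 for the measurement.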

Compound 3, intrinsic clearance in microsomes: < 3 mL.min-1.g-1
Compound 3: no number, only a limit (the forecaster's own chance of this, stated with the estimate: 60%); the middle value lies on the limit itself.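

In this assay compound 3 gives < 3 mL.min-1.g-1, a limit of the assay and not a number. Compound 1 is also reported only as a limit, so no step can be read between compound 1 and compound 3. The compounds shown leave open how their actual clearance values compare, and whether the group on the carbonyl carbon affects them.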